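Thiazolylmethylthio series: heteroaryl swap at the thiazole carbon

A few compounds are considered here, and "the series" means these few. Any claim that something is new, unique, unknown or untested is made for them only; others in the source may bear on it.

The series shares a common core bearing a nitrile-rich aminopyridine and a methoxyphenyl group; the variable part is the aryl ring carried by a five-membered aromatic ring with 1 nitrogen and 1 sulfur. Of the compounds shown here, two have been measured in an assay on CHO cells for displacement of a labelled ligand from adenosine receptor A1 (Homo sapiens); on this read-out lower numbers stand for stronger inhibition and higher numbers for weaker inhibition. Compound 1 `COc1ccc(-c2c(C#N)c(N)nc(SCc3csc(-c4ccc(Cl)c(Cl)c4)n3)c2C#N)cc1` gives 11 nM in this assay. Compound 2 `COc1ccc(-c2c(C#N)c(N)nc(SCc3nc(-c4ccc(Cl)cc4)sc3Br)c2C#N)cc1` gives 162 nM in this assay, a clearly weaker result, beyond the scatter; since the two structures differ in more than one place, nothing can be said about which change carries the loss. Compound 1 thus stands at the lowest number of the two.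

The next compound, compound 3 `COc1ccc(-c2c(C#N)c(N)nc(SCc3csc(-c4ccc(Br)cn4)n3)c2C#N)cc1`, carries 5-bromopyridin-2-yl in place of 3,4-dichlorophenyl on an aromatic carbon. Among the measured compounds shown here, no step between measured compounds isolates a change of this kind, so the expectation rests on the single value of compound 1 alone. A modest weakening is expected, with the step from compound 1 to compound 3 estimated as a 2.7-fold higher number from compound 1 to compound 3 (0.44 log units; beyond the scatter). Compound 3 is expected to give about 30 nM in this assay, with a range from 8 nM to 120 nM.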

Compound 3, inhibition constant: 53 nM
Compound 3: the middle estimate sits 1.8-fold (0.25 log units) below what was measured, within the range that was stated.
By their numbers in this assay, from the lowest: compound 1; then compound 3; then compound 2.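

In this assay, among the compounds shown here, this is the first comparison that differs in one place only, and it shows that the aryl group on the aromatic carbon of the five-membered aromatic ring with 1 nitrogen and 1 sulfur affects the read-out: 5-bromopyridin-2-yl in place of 3,4-dichlorophenyl gives a 4.8-fold higher number from compound 1 to compound 3 (0.68 log units; beyond the scatter). The step is modest, and compound 3 still gives 53 nM, so a six-membered aromatic ring with 1 hetero atom and 1 hydrogen-bond acceptor is compatible with a nanomolar read-out at this position, though it ranks behind 3,4-dichlorophenyl. The swap changes the ring and its halogens together, so the step cannot be divided between them, and no measurement bears on why the number rises.

From the compounds shown here alone, it remains open how much of the step belongs to the ring nitrogen and how much to the exchange of two chlorines for one bromine. A plain phenyl ring and an unsubstituted pyridine ring at this carbon would be the direct comparisons for separating the two contributions.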